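The source may report more compounds than this note shows. Statements on the series, on what has been measured and on what is new or still open speak of the compounds shown alone.

In an assay on isolated protein for inhibition of MAP kinase-activated protein kinase 5 (Homo sapiens), read by mobility shift assay, tested at 30 uM (on this read-out higher numbers stand for more inhibition at the one concentration tested (going by the name of the read-out) and lower numbers for less inhibition), compound 1, `Cn1nc(N)c2c(=O)[nH]c(-c3ccccc3)cc21`, gives 11%. Compound 2, `Cn1nc(N)c2c(=O)[nH]c(-c3ccccn3)cc21`, differs from compound 1 by one change, (pyridin-2-yl in place of phenyl on an aromatic carbon), and in this assay compound 2 gives 9%. The step here is a number 2 percentage points lower from compound 1 to compound 2 (within the scatter), so on this read-out the two compounds cannot be told apart.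

Compound 3, `Nc1c2c(=O)[nH]c(-c3ccccc3)cc2nn1-c1ccccc1`, carries a different core; how it differs from compound 1 is not broken down here. In this assay compound 3 gives 22%, which stands highest of the three measured numbers: both compound 1 and compound 2 lie below it, and both gaps are beyond the usual scatter.

Compound 4, `Nc1c2c(=O)[nH]c(-c3ccccn3)cc2nn1-c1ccccc1`, has not yet been measured. It differs from compound 3 by pyridin-2-yl in place of phenyl on an aromatic carbon, the same change, at the same kind of position, that turned compound 1 into compound 2. That change is seen twice among these compounds, and the one measured instance moved the read-out by a number 2 percentage points lower from compound 1 to compound 2 (within the scatter). Since that step lay within the scatter, the expectation for compound 4 rests on compound 3 staying roughly where it is, and the step from compound 3 to compound 4 is estimated as a number 2 percentage points lower from compound 3 to compound 4 (within the scatter). The estimated value for compound 4 in this assay is therefore 20%, expected to fall between 8% and 32%. Within the data shown here, the single precedent, compound 1 to compound 2, is a thin basis, and a larger shift in either direction cannot be excluded.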

Compound 4, a percentage reported as inhibition, at one concentration (the size of the read-out at that concentration, not a potency): 2%
Compound 4: the middle estimate sits 18 percentage points above what was measured; measured number below the stated range.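

In this assay, pyridin-2-yl in place of phenyl on an aromatic carbon of the core of compound 3 gives a number 20 percentage points lower from compound 3 to compound 4 (beyond the scatter). Set beside the same change on the core of compound 1, this shows that in this series the change does not carry from one core to the other with a fixed size: the same change on two cores in this assay, a number 2 percentage points lower (within the scatter) from compound 1 to compound 2 and a number 20 percentage points lower (beyond the scatter) from compound 3 to compound 4, 18 percentage points apart, beyond the scatter of two such steps It does not show why the two cores part, since there is only one pair on each core, the numbers come from a single concentration and are not potencies, and compound 1 at 11% had less room to fall on this read-out than compound 3 at 22%.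

The compounds shown leave open whether pyridin-3-yl or pyridin-4-yl in place of phenyl would follow pyridin-2-yl on either core, which would help separate the presence of the ring nitrogen from its place. Also open, on these data alone, is how the size of the step would change with a benzyl group or a longer alkyl chain where compound 1 carries its methyl and compound 3 its second phenyl.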